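Trifluoromethoxy in Place of Chloro: An Expected Inhibition Value

The source may report more compounds than this note shows. Statements on the series, on what has been measured and on what is new or still open speak of the compounds shown alone.

Of the compounds shown here, three sharing one core have been measured in an assay on isolated protein for inhibition of long-chain fatty acid transport protein 1 (Mus musculus); a higher number here means a weaker inhibitor, a lower number a stronger inhibitor. Compound 1 `CCn1c(CNc2ccccc2)nnc1SCc1nc2cc(F)ccc2o1` gives 7800 nM. Compound 2 `CCC(O)c1ccc2oc(CSc3nnc(CNc4ccccc4)n3CC)nc2c1` gives 3700 nM. Compound 3 `CCn1c(CNc2ccccc2)nnc1SCc1nc2cc(Cl)ccc2o1` gives 2300 nM, the lowest of the three numbers, though its gap to compound 2 lies within the scatter, while a 3.4-fold lower number from compound 1 to compound 3 (0.53 log units; beyond the scatter) and a 2.1-fold lower number from compound 1 to compound 2 (0.32 log units; beyond the scatter) both stand beyond it. The remaining comparison is a 1.6-fold lower number from compound 2 to compound 3 (0.21 log units; within the scatter).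

Compound 4 `CCn1c(CNc2ccccc2)nnc1SCc1nc2cc(OC(F)(F)F)ccc2o1` has not yet been measured. It differs from compound 3 in one place: trifluoromethoxy in place of chloro on an aromatic carbon. No measured step exchanges chloro for trifluoromethoxy, so the expectation rests on what this same position has shown. The fluoro-to-chloro exchange, a 3.4-fold lower number from compound 1 to compound 3 (0.53 log units; beyond the scatter), was modest, and the exchange of 1-hydroxypropyl for chloro, a 1.6-fold lower number from compound 2 to compound 3 (0.21 log units; within the scatter), stayed within the scatter; the largest change seen at this position thus moved the number only modestly. Compound 4 is therefore expected to land near compound 3. In this assay the expected step is a 1.2-fold lower number from compound 3 to compound 4 (0.06 log units; within the scatter), a change not expected to exceed the scatter. For compound 4 the value in this assay is estimated at 2000 nM, within a range from 700 nM to 6000 nM.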

Compound 4, half-maximal inhibitory concentration: 91 nM
Compound 4: middle estimate off by 22-fold (1.34 log units), on the high side, and the stated range ends above it.
By their numbers in this assay, from the lowest: compound 4; then compounds 3 and 2 (each within the scatter of the next); then compound 1.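

Measured in this assay the step of a 25-fold lower number from compound 3 to compound 4 (1.40 log units; beyond the scatter) shows that this place on the six-membered aromatic ring can move the number much further than fluoro, chloro and 1-hydroxypropyl had indicated, as those three groups had stayed within modest steps of one another. The other two comparisons point the same way, with a 41-fold lower number from compound 2 to compound 4 (1.61 log units; beyond the scatter) and an 86-fold lower number from compound 1 to compound 4 (1.93 log units; beyond the scatter) both large and beyond the scatter, so that compound 4 stands clearly apart from all three earlier compounds. The small differences among three groups at this place therefore set no limit on what a fourth group there could do, and the position is far more sensitive to the choice of group than the first three values suggested.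

From the compounds shown here alone, whether methoxy, trifluoromethyl or difluoromethoxy at this place would give a number like that of compound 4 stays open, as does whether the low number would hold with trifluoromethoxy kept and a change made elsewhere on the shared core. Among these compounds, nothing at hand gives a reason why this one exchange moves the number so far.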